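Dimethylphenyl Sulfonamide Awaits Its Antiproliferative Reading

The compounds below may be only part of what the source reports. "The series", "measured", "known", "first", "only" and "open" are said of these compounds alone.

Three aryl sulfonamides sharing one core have been measured in a functional assay on M21 cells (Homo sapiens) for antiproliferative activity, read by sulforhodamine B assay, with a stated time of 48 h; on this read-out lower numbers stand for stronger inhibition and higher numbers for weaker inhibition. Compound 1 `O=C1NCCN1c1ccc(S(=O)(=O)Nc2cccc(Br)c2)cc1` gives 59 nM. Compound 2 `Cc1ccccc1NS(=O)(=O)c1ccc(N2CCNC2=O)cc1` gives 150 nM, and compound 3 `COc1ccccc1NS(=O)(=O)c1ccc(N2CCNC2=O)cc1` gives 300 nM, the highest number of the three. The steps leading to it are a 5.1-fold higher number from compound 1 to compound 3 (0.71 log units; beyond the scatter) and a 2.0-fold higher number from compound 2 to compound 3 (0.30 log units; within the scatter), while a 2.5-fold higher number from compound 1 to compound 2 (0.41 log units; beyond the scatter) describes the remaining pair.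

Compound 4 `Cc1cc(C)cc(NS(=O)(=O)c2ccc(N3CCNC3=O)cc2)c1` differs from compound 3 by 3,5-dimethylphenyl in place of 2-methoxyphenyl on a sulfonamide nitrogen. For the measured compounds named here, no measured step exchanges a ring substitution pattern for this one directly, so the bearing steps are indirect: the 3-bromophenyl of compound 1 stands at the low end, and both of its replacements by substituted phenyl rings, in compound 2 and compound 3, raised the number by modest amounts. Since compound 1 holds the lowest number at 59 nM, compound 4 is expected to show a modest downward step a 2.5-fold lower number from compound 3 to compound 4 (0.40 log units; beyond the scatter), with considerable uncertainty. Compound 4 is therefore estimated at 120 nM, within a range from 40 nM to 350 nM.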

Compound 4, half-maximal inhibitory concentration: 63 nM
The estimate for compound 4 lay 1.9-fold (0.28 log units) above the measured number, and the stated range covers the measured number.
By their numbers in this assay, from the lowest: compounds 1 and 4 (each within the scatter of the next); then compounds 2 and 3 (each within the scatter of the next).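

In this assay, moving to the 3,5-dimethylphenyl on the sulfonamide nitrogen gives a 4.8-fold lower number from compound 3 to compound 4 (0.68 log units; beyond the scatter) and a 2.4-fold lower number from compound 2 to compound 4 (0.38 log units; beyond the scatter), so a phenyl ring carrying methyl groups at this position need not share the higher numbers of the 2-methylphenyl and 2-methoxyphenyl rings. The further comparison, a 1.1-fold higher number from compound 1 to compound 4 (0.03 log units; within the scatter), shows that the 3-bromophenyl ring is no longer alone at the low end, and that a ring made of carbon and hydrogen only can match it within the scatter. Nothing measured here accounts for these differences.

The compounds shown leave open how a phenyl ring bearing an amine or a carboxylic acid would read at this sulfonamide nitrogen. As far as these compounds go, whether both methyl groups of the 3,5-dimethylphenyl are needed for its reading also stays open.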